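Ester to Amide in a Neutrophil Inhibitor Series

A few compounds are considered here, and "the series" means these few. Any claim that something is new, unique, unknown or untested is made for them only; others in the source may bear on it.

Measured compounds:
Compound 1, `CCOC(=O)c1cnn2c1N(C(=O)Nc1ccccc1)C(c1ccccc1)C2`, gives 98 nM in a functional assay on cells (Neutrophil, Homo sapiens) for inhibition, with a stated time of 10 min; on this read-out higher numbers stand for weaker inhibition and lower numbers for stronger inhibition.
Compound 2, `CCOC(=O)c1cnn2c1N(C(=O)Nc1ccccc1F)C(c1ccccc1)C2`, gives 116 nM in this assay.
Compound 3, `CCOC(=O)c1cnn2c1N(C(=O)Nc1cccc3ccccc13)C(c1ccccc1)C2`, gives 13.8 nM in this assay.

Among the three, compound 3 stands lowest. The steps leading to it are a 7.1-fold lower number from compound 1 to compound 3 (0.85 log units; beyond the scatter) and an 8.4-fold lower number from compound 2 to compound 3 (0.92 log units; beyond the scatter), both beyond the scatter, whereas a 1.2-fold higher number from compound 1 to compound 2 (0.07 log units; within the scatter) stays within it. Compound 4, `NC(=O)c1cnn2c1N(C(=O)Nc1cccc3ccccc13)C(c1ccccc1)C2`, keeps the naphthalen-1-yl group of compound 3 and alters only the ester: amino in place of ethoxy on a carbonyl carbon, which reads, cut one bond further out, as ethoxycarbonyl to carbamoyl. Within the data shown here, none of the measured steps touches this position; all three concern the group on the amide-type nitrogen. No direction can be drawn from them, so the estimate rests on compound 3 alone with a wide band. The expected step is a 2.2-fold higher number from compound 3 to compound 4 (0.34 log units; beyond the scatter). Compound 4 is thus estimated at 30 nM in this assay, between 8 nM and 120 nM.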

Compound 4, half-maximal inhibitory concentration: 110 nM
Compound 4: middle estimate off by 3.7-fold (0.56 log units), on the low side; low and high end bracket the measured number.
By their numbers in this assay, from the lowest: compound 3; then compounds 1, 4 and 2 (each within the scatter of the next).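

The ester position matters: with the naphthalen-1-yl group held fixed, amino in place of ethoxy on the carbonyl carbon gives an 8.0-fold higher number from compound 3 to compound 4 (0.90 log units; beyond the scatter) in this assay. Among these compounds, the earlier steps all concerned the group on the amide-type nitrogen, so this is the first sign that the carbonyl substituent also moves the read-out. No measurement here explains this loss of inhibition.

Still open, going by these compounds, is how a carboxylic acid, a methoxy group or a methylamino group would behave on this carbonyl carbon. It is also unclear whether the same swap would have a similar effect with phenyl on the amide-type nitrogen.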